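Swapping trifluoromethyl for methyl on compound 2

A few compounds are considered here, and "the series" means these few. Any claim that something is new, unique, unknown or untested is made for them only; others in the source may bear on it.

Compound 1 `Cc1ccc(-c2nc3cccnc3n2CC(N)=O)cc1` gives 50.5 mg/kg
Compound 2 `CN(C)C(=O)Cn1c(-c2ccc(C(F)(F)F)cc2)nc2cccnc21` gives 3.2 mg/kg

Both numbers come from a functional assay on the whole organism with Mus musculus as the target (a lower number here means that less compound is needed, a higher number that more compound is needed for the effect), and compound 2 holds the lower of the two (3.2 mg/kg), so less of it is needed. Its gap to compound 1 (50.5 mg/kg) lies beyond the scatter of repeated measurements. The two compounds differ in more than one place, so that gap cannot be pinned on any single group.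

Compound 3 `Cc1ccc(-c2nc3cccnc3n2CC(=O)N(C)C)cc1` stays close to compound 2, with methyl in place of trifluoromethyl on an aromatic carbon. Among the measured compounds shown here, no measured pair shows this change alone, which leaves the expected size of the step in this assay resting on thin evidence. For the measured compounds named here, the only hint is that compound 1, which also carries methyl, sits at the higher number (50.5 mg/kg). A moderate rise is therefore expected, though a result within the scatter remains possible. The estimated step is a 3.1-fold higher number from compound 2 to compound 3 (0.49 log units; beyond the scatter) in the direction of more compound needed. For compound 3 the estimate is 10 mg/kg (expected range 3 mg/kg to 35 mg/kg).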

Compound 3, dose for half-maximal effect: 4.7 mg/kg
Beside the measured number, compound 3's estimate is 2.1-fold (0.33 log units) above it, within the range that was stated.
By their numbers in this assay, from the lowest: compounds 2 and 3 (each within the scatter of the next); then compound 1.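

In this assay, methyl in place of trifluoromethyl on the aromatic carbon gives a 1.5-fold higher number from compound 2 to compound 3 (0.17 log units; within the scatter), so in this pair the exchange at this position has no effect that can be told from the scatter. The change on the carbonyl carbon, dimethylamino in place of amino, gives an 11-fold lower number from compound 1 to compound 3 (1.03 log units; beyond the scatter), a large step. Compound 3 therefore links compound 1 and compound 2, which differ in two places, and shows that among these three compounds the gap follows the group on the carbonyl carbon rather than the group on the aromatic carbon, although no measurement here offers an explanation for this.

The compounds shown leave open whether other groups on the aromatic carbon, such as a chlorine atom or a methoxy group, would also stay within the scatter of compound 2 and compound 3. They also leave open where methylamino or a ring amine such as pyrrolidine would fall on the carbonyl carbon, and whether the step from amino to dimethylamino keeps its size with trifluoromethyl on the aromatic carbon.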